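The source may report more compounds than this note shows. Statements on the series, on what has been measured and on what is new or still open speak of the compounds shown alone.

Measured in the series:
- compound 1 `Clc1ccc(N2CC3CC(C2)N3)cn1` — in an assay on a protein complex (strain Sprague-Dawley) for agonist activity at Neuronal acetylcholine receptor; alpha4/beta2 (Rattus norvegicus), read by scintillation counting, with a stated time of 5 min (a lower number here means that less compound is needed, a higher number that more compound is needed for the effect), compound 1 gives 1.16 nM
- compound 2 `Clc1cncc(N2CC3CC(C2)N3)c1` — in this assay compound 2 gives 1.4 nM

Within the data shown here, compound 2 holds the higher of the two numbers so far, but its nearest neighbour, compound 1, sits within the scatter of it, so the two cannot be ordered. Both share the same core and differ only in where the chloro sits on the pyridine-type ring.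

Compound 3 `c1ccc(-c2cncc(N3CC4CC(C3)N4)c2)cc1` is not yet measured. Relative to compound 2 the change is phenyl in place of chloro on an aromatic carbon, two atoms from the ring nitrogen and meta to the group of 7 heavy atoms. Among the measured compounds shown here, no measured pair in this set shows a step of this kind, so no comparison number exists for it. A larger substituent entering at that carbon is expected to raise the number, that is, to cost activity, by more than the scatter. The expected step of a 7.1-fold higher number from compound 2 to compound 3 (0.85 log units; beyond the scatter) reflects this. For compound 3 the estimate in this assay is 10 nM, with a range from 2 nM to 60 nM.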

Compound 3, half-maximal effective concentration: "not active" (no number reported)
For compound 3 the study gives words and no number, so the estimate cannot be set against anything.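

Among these compounds, compound 3 is reported in this assay as "not active", with no number, so no step from compound 2 to compound 3 can be read. The compounds shown leave open how large the effect of phenyl in place of chloro is, and no evidence here bears on this result.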